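From 2-Methoxyethoxy to Benzylamino: Expected Cytotoxicity

This account rests on a few compounds, and the source may have more. Where it says the series, first, only, none or still open, it means among the compounds named here.

Compound 2 `COCCOC(=O)Nc1cc2nc(C3CCCCC3)[nH]c2cc1N1CCCC1` has been tested in an ADME assay on Vero cells (Chlorocebus sabaeus) for cytotoxicity, read by resazurin assay, with a stated time of 3 days (a higher number here means a weaker inhibitor, a lower number a stronger inhibitor), alongside compound 1 `CN(C)c1cc2[nH]c(C3CCCCC3)nc2cc1NC(=O)c1ccccc1` and compound 3 `COc1ccc(C(=O)Nc2cc3nc(C4CCCCC4)[nH]c3cc2N(C)C)cc1`. In this assay compound 2 gives > 100 ug/mL, which is a limit of the assay rather than a number. Compound 1 gives > 100 ug/mL, again a limit. Compound 3 gives > 100 ug/mL, also a limit. Compound 2 therefore stands exactly where the other two measured compounds stand, at the limit of > 100 ug/mL in this assay, at which 3 of the 3 values shown sit. Within the data shown here, the only measured single-point change, a step that the two limits leave unreadable from compound 1 to compound 3, cannot be read for size, as both of its ends are limits.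

Compound 4 `O=C(NCc1ccccc1)Nc1cc2nc(C3CCCCC3)[nH]c2cc1N1CCCC1` is not yet measured. It differs from compound 2 in this way: benzylamino in place of 2-methoxyethoxy on a carbonyl carbon. Among the measured compounds shown here, no measured step bears directly on this change, and the one step that has been measured does not show a size. For the measured compounds named here, since every value so far sits at the limit of > 100 ug/mL in this assay, at which 3 of the 3 values shown sit, compound 4 is expected to behave the same way, with the step that the limit leaves unreadable from compound 2 to compound 4 expected to be none beyond the scatter. Compound 4 is estimated at 120 ug/mL, within a range from 50 ug/mL to 300 ug/mL.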

Compound 4, half-maximal inhibitory concentration: > 100 ug/mL
Compound 4 was reported as a limit (the forecaster's own chance of this, stated with the estimate: 80%); the middle value lies beyond the limit too.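

Compound 2 and compound 4 both stand at a limit in this assay rather than at a number, so the size of the step between them cannot be read. The four compounds shown leave open at what concentration any of them would register in this assay and whether any of these changes alters that.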